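The compounds below may be only part of what the source reports. "The series", "measured", "known", "first", "only" and "open" are said of these compounds alone.

Of the compounds shown here, three built on one shared core have been tested in a functional assay on PC-3 cells (Homo sapiens) for cytotoxicity, read by MTT assay, with a stated time of 48 h; on this read-out lower numbers stand for stronger inhibition and higher numbers for weaker inhibition. Compound 3 `COc1cc(-c2nnc3n2NC(c2ccco2)C(C(=O)c2ccc(C)cc2)S3)cc(OC)c1OC` gives 7500 nM, the lowest number of the three. Compound 1 `COc1cc(-c2nnc3n2NC(c2ccco2)C(C(=O)c2ccc(F)c(F)c2)S3)cc(OC)c1OC` gives 36000 nM and compound 2 `COc1cc(-c2nnc3n2NC(c2ccco2)C(C(=O)c2ccco2)S3)cc(OC)c1OC` gives 58300 nM; the change between them and compound 3 is modest, as in a 7.8-fold lower number from compound 2 to compound 3 (0.89 log units; beyond the scatter). Compound 4 `COc1cc(-c2nnc3n2NC(c2ccco2)C(C(=O)c2ccc(C(F)(F)F)cc2)S3)cc(OC)c1OC` differs from compound 3 by trifluoromethyl in place of methyl on an aromatic carbon. Among the compounds with values here, no measured step exchanges methyl for trifluoromethyl, so there is no direct guide; the nearest hint is a 4.8-fold lower number from compound 1 to compound 3 (0.68 log units; beyond the scatter), where the ring carrying fluorine gave the higher number. A small rise in this assay, near the edge of the scatter, is therefore expected. For compound 4 the estimate is 12000 nM, ranging from 4000 nM to 40000 nM. The expected step is a 1.6-fold higher number from compound 3 to compound 4 (0.20 log units; within the scatter).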

Compound 4, half-maximal inhibitory concentration: 77500 nM
Beside the measured number, compound 4's estimate is 6.5-fold (0.81 log units) below it, outside the stated range (above it).
By their numbers in this assay, from the lowest: compound 3; then compounds 1, 2 and 4 (each within the scatter of the next, the first and the last beyond it).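

Trifluoromethyl in place of methyl on this ring gives a 10-fold higher number from compound 3 to compound 4 (1.01 log units; beyond the scatter), so one small group at this position can carry a large step. The low number of compound 3 therefore does not come with every substituted phenyl group on the carbonyl: a 1.3-fold higher number from compound 2 to compound 4 (0.12 log units; within the scatter) stays within the scatter, while a 2.2-fold higher number from compound 1 to compound 4 (0.33 log units; beyond the scatter) lies just beyond it. Methyl is the only group shown here that gives a clear drop.

On these data alone, whether an amine or a longer chain at this position would keep the low number remains open. Nothing available explains the size of this step.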